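The compounds below may be only part of what the source reports. "The series", "measured", "known", "first", "only" and "open" are said of these compounds alone.

Compound 1 `c1ccc(N2N=C(c3ccc4c(c3)OCCO4)CC2c2cccc3ccccc23)cc1` carries naphthalen-1-yl on the saturated ring carbon of the shared core. In a functional assay on WM 266-4 cells (Homo sapiens) for antiproliferative activity, read by MTT assay, with a stated time of 24 h (on this read-out lower numbers stand for stronger inhibition of growth and higher numbers for weaker inhibition of growth), compound 1 gives only > 100000 nM, which is a limit of the assay and not a number; compound 1 thus stands at the limit of > 100000 nM in this assay, at which 1 of the 2 values shown sits. Compound 2 `c1ccc(COc2cccc(C3CC(c4ccc5c(c4)OCCO5)=NN3c3ccccc3)c2)cc1` gives in this assay a value of 870 nM. Compound 3 `Brc1ccc(C2CC(c3ccc4c(c3)OCCO4)=NN2c2ccccc2)cc1` has not been measured; it differs from compound 1 by 4-bromophenyl in place of naphthalen-1-yl on a saturated ring carbon. For the measured compounds named here, since compound 1 sits at a limit, no measured step gives the size of this change; a move toward stronger inhibition of growth is expected, though its size is uncertain. Compound 3 is expected at 8000 nM, within 1500 nM to 60000 nM, an expected step of an at least 12-fold lower number from compound 1 to compound 3 (1.09 log units; beyond the scatter).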

Compound 3, concentration for 50% growth inhibition: 3010 nM
Compound 3: middle estimate off by 2.7-fold (0.42 log units), on the high side, within the range that was stated.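

Replacing naphthalen-1-yl with 4-bromophenyl on the saturated ring carbon gives an at least 33-fold lower number from compound 1 to compound 3 (1.52 log units; beyond the scatter) in this assay, so this position can carry a single-ring group and return a measurable value. The true size of the step remains unknown, since compound 1 stands at a limit and not a number: the limit of > 100000 nM in this assay, at which 1 of the 3 values shown sits.

The compounds shown leave open whether the step goes with the bromine or with the change from two aromatic rings to one. Plain phenyl or 4-aminophenyl at this carbon would separate the two.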